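Swapping the charged ring system at the chain end

This account rests on a few compounds, and the source may have more. Where it says the series, first, only, none or still open, it means among the compounds named here.

Compound 1 `Cc1ccc(-n2cc(C(=O)Nc3cc(F)cc(F)c3)c(=O)c3ccc(N(C)C)nc32)cc1OCCCCCCC[N+]12CCN(CC1)CC2` gives 5.07% in an assay on LX2 cells for inhibition of COL1A1 promoter (Homo sapiens), read by a luciferase reporter, with a stated time of 24 h, tested at 20 uM (a higher number here means a stronger effect of the compound at the concentration tested, a lower number a weaker effect), the lowest of the three measured values; compound 2 `CN(C)c1ccc2c(=O)c(C(=O)Nc3cc(F)cc(F)c3)cn(-c3ccc(Cl)c(OCCCCCCC[N+]45CCN(CC4)CC5)c3)c2n1` gives 8.08%, and compound 3 `CC[N+]1(CCCCCCCOc2cc(C)cc(-n3cc(C(=O)Nc4cc(F)cc(F)c4)c(=O)c4ccc(N(C)C)nc43)c2)CCCCC1` gives 67.2%. The step of a number 3 percentage points higher from compound 1 to compound 2 (within the scatter) concerns the aromatic ring only. Compound 4 `CC[N+]1(CCCCCCCOc2cc(-n3cc(C(=O)Nc4cc(F)cc(F)c4)c(=O)c4ccc(N(C)C)nc43)ccc2C)CCCC1` differs from compound 1 by a group of 7 heavy atoms (6 carbon, 1 nitrogen; one five-membered non-aromatic ring with 1 hetero atom) in place of a group of 8 heavy atoms (6 carbon, 2 nitrogen; 2 six-membered non-aromatic rings with 2 hetero atoms each), on a saturated chain carbon, seven bonds along the chain from an oxygen on an aromatic ring. Among the compounds with values here, no measured step changes this part alone: compound 3 also carries a single-ring charged group, but it differs from compound 1 elsewhere too, so its high value cannot be assigned to the chain end. The expected change is therefore uncertain, with the estimated step of a number 29.9 percentage points higher from compound 1 to compound 4 (beyond the scatter) leaning upward. Compound 4 is estimated at 35%, within 5% to 70%.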

Compound 4, a percentage reported as inhibition, at one concentration (the size of the read-out at that concentration, not a potency): 57%
The estimate for compound 4 lay 22 percentage points below the measured number; the range from low to high includes it.
By their numbers in this assay, from the lowest: compounds 1 and 2 (each within the scatter of the next); then compound 4; then compound 3.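

In this assay, within the data shown here, the chain end alone accounts for a number 51.9 percentage points higher from compound 1 to compound 4 (beyond the scatter), so this is the first measured evidence that the group at this position can change the read-out on an otherwise unchanged compound. The step does not come with a change in net charge, which is +1 for both the group that leaves and the group that enters. Nothing measured here explains why the single five-membered ring gives the larger effect. From the compounds shown here alone, whether a trimethylammonium group at the chain end, or a shorter chain carrying the same five-membered ring, would match compound 4 stays open.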